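Replacing a carbamoyl group in an inactive pyrrole-type series

The source may report more compounds than this note shows. Statements on the series, on what has been measured and on what is new or still open speak of the compounds shown alone.

Measured so far in an assay for inhibition of Polyunsaturated fatty acid lipoxygenase ALOX15 (Homo sapiens), with a stated time of 10 min; on this read-out higher numbers stand for weaker inhibition and lower numbers for stronger inhibition:
compound 1 `Nc1[nH]c(C(=O)c2ccccc2)c(-c2cccc3ccccc23)c1C(=O)c1ccc(Cl)c(Cl)c1` gives > 100000 nM, a limit of the assay.
compound 2 `Nc1[nH]c(C(=O)c2ccccc2)c(-c2cccc(Cl)c2)c1C(=O)c1cccc(Cl)c1` gives > 100000 nM, a limit of the assay.
compound 3 `NC(=O)c1c(N)[nH]c(C(=O)c2ccccc2)c1-c1ccc(Cl)cc1Cl` gives > 100000 nM, a limit of the assay.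

Compound 3 therefore stands where every value shown stands: at the limit of > 100000 nM in this assay, at which 3 of the 3 values shown sit. No difference in this assay between any two of the three compounds can be read from these limits.

Compound 4 `Cc1cccc(C(=O)c2c(N)[nH]c(C(=O)c3ccccc3)c2-c2ccc(Cl)cc2Cl)c1` differs from compound 3 in one place: 3-methylphenyl in place of amino on a carbonyl carbon. Going by the values given here, since each measured compound sits at the limit, no measured step guides this change. The expectation for this assay is no step beyond the scatter, with a limit the most likely result again, so the expected step from compound 3 to compound 4 is a step that the limit leaves unreadable from compound 3 to compound 4. Compound 4 is estimated at 150000 nM, within 40000 nM to 1000000 nM.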

Compound 4, half-maximal inhibitory concentration: > 100000 nM
Compound 4 was reported as a limit; the forecaster's own chance of this, stated with the estimate: 80%; the middle value is on the limit's open side.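

No step from compound 3 to compound 4 can be read, because both sit at a limit of the assay: the limit of > 100000 nM in this assay, at which 4 of the 4 values shown sit.

The compounds shown leave open which change to the shared core, if any, would give a measurable value in this assay.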